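Lengthening the Chain on a Chlorinated Compound

The source may report more compounds than this note shows. Statements on the series, on what has been measured and on what is new or still open speak of the compounds shown alone.

Values in a functional assay on HL60/MX2 cells (Homo sapiens) for antiproliferative activity, read by MTT assay, with a stated time of 48 h; a higher number here means a weaker inhibitor, a lower number a stronger inhibitor:
- Compound 1 `CN(C)CCn1c(N)c(-c2nc3ccccc3[nH]2)c2nc(C#N)c(C#N)nc21`: 3780 nM
- Compound 2 `CN(C)CCCCn1c(N)c(-c2nc3ccccc3n2C)c2nc(C#N)c(C#N)nc21`: 2580 nM
- Compound 3 `CN(C)CCn1c(N)c(-c2nc3cc(Cl)ccc3[nH]2)c2nc(C#N)c(C#N)nc21`: > 50000 nM

Compound 3 gives only a limit of the assay, > 50000 nM, and no number. Compound 4 `CN(C)CCCCn1c(N)c(-c2nc3cc(Cl)ccc3[nH]2)c2nc(C#N)c(C#N)nc21` keeps the chloro of compound 3 and changes the chain: 2-(dimethylamino)ethyl in place of dimethylamino on a saturated chain carbon, two bonds along the chain from an aromatic nitrogen. It has 2-(dimethylamino)ethyl in place of dimethylamino on a saturated chain carbon, two bonds along the chain from an aromatic nitrogen, so that a 2-(dimethylamino)ethyl chain becomes a 4-(dimethylamino)butyl chain.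

Going by the values given here, no measured step changes the chain alone. Among the compounds with values here, the one measured step, an at least 13-fold higher number from compound 1 to compound 3 (1.12 log units; beyond the scatter), puts chloro in place of hydrogen on an aromatic carbon and is large, but it leaves the chain as it is. Compound 2 carries the 4-(dimethylamino)butyl chain and an extra methyl, and it gives 2580 nM. Compound 1, with the shorter chain, gives 3780 nM, within the scatter of the value of compound 2. In this assay, a large step towards a lower number is therefore expected, although its size is poorly defined. The estimated change is an at least 5.0-fold lower number from compound 3 to compound 4 (0.69 log units; beyond the scatter). For compound 4 the estimate is 10000 nM, with an expected range from 2000 nM to 50000 nM.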

Compound 4, half-maximal inhibitory concentration: 580 nM
Compound 4: the middle estimate sits 17-fold (1.24 log units) above what was measured; the measured number lies below the stated range.
By their numbers in this assay, from the lowest: compound 4; then compounds 2 and 1 (each within the scatter of the next). At a limit, above all of these: compound 3.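

Going by these compounds alone, with the chloro held in place in this assay, 2-(dimethylamino)ethyl in place of dimethylamino on a saturated chain carbon, two bonds along the chain from an aromatic nitrogen, gives an at least 86-fold lower number from compound 3 to compound 4 (1.93 log units; beyond the scatter), the first measured step that changes the chain alone. The size of this step is a bound and not an exact figure, because compound 3 stands at a limit of the assay and gives no number: the limit of > 50000 nM in this assay, at which 1 of the 4 values shown sits. The large rise that came with the chloro on the 2-(dimethylamino)ethyl chain does not appear on the 4-(dimethylamino)butyl chain, where 5-chloro-1H-benzimidazol-2-yl in place of 1-methyl-1H-benzimidazol-2-yl gives a 4.4-fold lower number from compound 2 to compound 4 (0.65 log units; beyond the scatter), a swap that also removes the methyl.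

Compound 1 and compound 2 differ in that methyl as well as in the chain, so what the longer chain does without the chloro remains unread. Also open, from the compounds shown here alone, is how a 3-(dimethylamino)propyl chain, a chain longer than butyl, a piperidine or morpholine in place of the dimethylamino, or a fluoro or bromo in place of the chloro would read in this assay.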